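Replacing the cycloheptyl group of compound 3

The source may hold more compounds than are shown below. What is called first, only, known or untested is meant among the compounds shown, and "the series" means these compounds.

Of the compounds shown here, three sharing one core have been measured in an ADME assay on MRC5 cells (Homo sapiens) for inhibition, with a stated time of 72 h; a lower number here means that less compound is needed, a higher number that more compound is needed for the effect. Compound 1 (`COc1cccc(OC)c1C(=O)Nc1c[nH]nc1C(=O)N[C@H]1CC[C@H](O)CC1`), with 4-hydroxycyclohexyl on the amide-type nitrogen, gives 34000 nM. Compound 2 (`COc1cccc(OC)c1C(=O)Nc1c[nH]nc1C(=O)O`), with hydroxy on the carbonyl carbon, reads > 50000 nM, which is a limit of the assay and not a number. Compound 3 (`COc1cccc(OC)c1C(=O)Nc1c[nH]nc1C(=O)NC1CCCCCC1`), with cycloheptyl on the amide-type nitrogen, gives 42000 nM. It cannot be told apart from the other measured amide, the comparison being a 1.2-fold higher number from compound 1 to compound 3 (0.09 log units; within the scatter).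

Compound 4 (`COc1cccc(OC)c1C(=O)Nc1c[nH]nc1C(=O)NCCCN(C)C`) puts 3-(dimethylamino)propyl in place of cycloheptyl on the amide-type nitrogen: 3-(dimethylamino)propyl in place of cycloheptyl on an amide-type nitrogen. Among the measured compounds shown here, the nearest precedent is the same exchange of amide substituent, a 1.2-fold higher number from compound 1 to compound 3 (0.09 log units; within the scatter). The larger changes at this carbonyl carbon are an at least 1.4-fold higher number from compound 1 to compound 2 (0.16 log units; that floor lies within the scatter) and an at least 1.1-fold lower number from compound 2 to compound 3 (0.07 log units; that floor lies within the scatter), and neither shows a step beyond the scatter. No step beyond the scatter is therefore expected in this assay. The expected step is a 1.1-fold lower number from compound 3 to compound 4 (0.02 log units; within the scatter). For compound 4 the estimated value is 40000 nM, with an expected range of 18000 nM to 50000 nM. The readings are bounded by the limit of > 50000 nM in this assay, at which 1 of the 3 values shown sits, so compound 4 may also be reported only as a limit.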

Compound 4, half-maximal effective concentration: > 50000 nM
Compound 4 ended at the assay's limit; the forecaster's own chance of this, stated with the estimate: 35%; at least 1.2-fold (0.09 log units) between middle value and limit.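

In this assay, exchanging the cycloheptyl ring for 3-(dimethylamino)propyl, which has no ring and brings in a nitrogen, gives an at least 1.1-fold higher number from compound 3 to compound 4 (0.07 log units; that floor lies within the scatter), and exchanging the 4-hydroxycyclohexyl group for the same chain gives an at least 1.4-fold higher number from compound 1 to compound 4 (0.16 log units; that floor lies within the scatter). From the compounds shown here alone, compound 4 reads a limit of the assay and not a number, so the true size of both steps stays unknown and could lie beyond the scatter, which neither of the measured amides had left possible between themselves. The step from compound 2 to compound 4 cannot be read, and the upper end of this assay now restricts what can be compared at this carbonyl carbon: the limit of > 50000 nM in this assay, at which 2 of the 4 values shown sit.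

The compounds shown do not separate the loss of the ring from the entry of the dimethylamino nitrogen, a question that a plain alkyl chain on the same amide-type nitrogen would address. Going by these compounds, whether a primary amine or a morpholine at the end of the chain would give a reading short of the limit also remains open.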